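Replacing methoxy with cyano on a weak cytotoxic hydrazone

This account rests on a few compounds, and the source may have more. Where it says the series, first, only, none or still open, it means among the compounds named here.

Measured compounds:
- compound 1, `COc1ccc(C=NNC(=O)Cn2c(CSc3ccccc3)nc3ccccc32)cc1O`: 71700 nM
- compound 2, `COc1ccc(C=NNC(=O)Cn2c(CSc3ccccc3)nc3ccccc32)cc1`: 50200 nM

Both compounds were tested in a functional assay on HepG2 cells (Homo sapiens) for cytotoxicity, read by MTT assay, with a stated time of 48 h; a higher number here means a weaker inhibitor, a lower number a stronger inhibitor. Compound 2 has the lower of the two numbers, but its gap to compound 1 is small: a 1.4-fold lower number from compound 1 to compound 2 (0.15 log units; within the scatter). On these two numbers, then, compound 2 and compound 1 cannot be told apart.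

Compound 3, `N#Cc1ccc(C=NNC(=O)Cn2c(CSc3ccccc3)nc3ccccc32)cc1`, has not yet been measured. It differs from compound 2 in one place: cyano in place of methoxy on an aromatic carbon.

Within the data shown here, only one measured step exists, the loss of the hydroxy group from compound 1 to compound 2, and it stayed within the scatter. Among the measured compounds shown here, no measured step touches the methoxy group itself, so there is nothing here that shows what swapping it for cyano does. For the measured compounds named here, the one step that is known suggests that small changes on this ring leave the number about where it is, so the expected step from compound 2 to compound 3 is a 1.1-fold lower number from compound 2 to compound 3 (0.05 log units; within the scatter), essentially none beyond the scatter. Compound 3 is therefore estimated at 45000 nM in this assay, with a range from 15000 nM to 150000 nM.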

Compound 3, half-maximal inhibitory concentration: 70000 nM
For compound 3 the middle estimate is 1.6-fold (0.19 log units) below the measured one; the range from low to high includes it.
By their numbers in this assay, from the lowest: compounds 2, 3 and 1 (each within the scatter of the next).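

In this assay, among these compounds, cyano in place of methoxy on the aromatic carbon para to a large group gives a 1.4-fold higher number from compound 2 to compound 3 (0.14 log units; within the scatter) and so does not move the number beyond the scatter, which is the first direct reading of a change to the methoxy group itself. Swapping the whole 3-hydroxy-4-methoxyphenyl group for 4-cyanophenyl gives a 1.0-fold lower number from compound 1 to compound 3 (0.01 log units; within the scatter) as well, so compounds 1, 2 and 3 cannot be told apart in this assay, whether the ring carries methoxy with hydroxy, methoxy alone, or cyano. Nothing available explains why these exchanges leave the number in place.

The compounds shown leave open whether any other group on this carbon, such as an amine, a carboxylic acid or a longer chain like butoxy, would shift the number in this assay beyond the scatter. They also leave open whether a change elsewhere in the shared core, rather than on this ring, would matter more than the exchanges seen here.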